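Methoxy in Place of Chloro: What to Expect

A few compounds are considered here, and "the series" means these few. Any claim that something is new, unique, unknown or untested is made for them only; others in the source may bear on it.

Compound 1 `O=C(CCC(=O)OCCCCCCSc1ccc([N+](=O)[O-])c2nonc12)Nc1ccccc1` and compound 2 `O=C(CCC(=O)OCCCCCCSc1ccc([N+](=O)[O-])c2nonc12)Nc1ccccc1Cl` share the same core and differ in a single group on an aromatic carbon. In an ADME assay on L02 cells (Homo sapiens) for cytotoxicity, read by MTT assay, with a stated time of 72 h (on this read-out higher numbers stand for weaker inhibition and lower numbers for stronger inhibition), compound 1 gives 6490 nM, and compound 2 gives 5850 nM. Among the measured compounds shown here, the step of a 1.1-fold lower number from compound 1 to compound 2 (0.05 log units; within the scatter) is within the scatter, so compound 2 and compound 1 cannot be told apart on these numbers, and no other measured compound exists to place compound 2 against.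

Compound 3 `COc1ccccc1NC(=O)CCC(=O)OCCCCCCSc1ccc([N+](=O)[O-])c2nonc12` keeps the core of compound 2 and carries methoxy in place of chloro on an aromatic carbon. For the measured compounds named here, only one measured step bears on this change, namely a 1.1-fold lower number from compound 1 to compound 2 (0.05 log units; within the scatter), in which the chloro group came in without moving the number beyond the scatter. Exchanging that chloro group for methoxy is therefore expected to leave the number near where compound 2 sits, with no step beyond the scatter in either direction, an expected 1.0-fold higher number from compound 2 to compound 3 (0.01 log units; within the scatter). Compound 3 is estimated at 6000 nM, with a range from 2500 nM to 14000 nM.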

Compound 3, half-maximal inhibitory concentration: 4490 nM
Beside the measured number, compound 3's estimate is 1.3-fold (0.13 log units) above it, and the stated range covers the measured number.
By their numbers in this assay, from the lowest: compounds 3, 2 and 1 (each within the scatter of the next).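

In this assay, exchanging chloro for methoxy gives a 1.3-fold lower number from compound 2 to compound 3 (0.11 log units; within the scatter), and methoxy in place of hydrogen gives a 1.4-fold lower number from compound 1 to compound 3 (0.16 log units; within the scatter), so neither step leaves the scatter. This place on the aromatic ring, ortho to a large group, has now carried hydrogen, chloro and methoxy, and compound 1, compound 2 and compound 3 cannot be told apart on these numbers; what the first pair showed for chloro alone now also holds for methoxy, a group that brings a hydrogen-bond acceptor which chloro does not have. Nothing measured here offers an explanation for these numbers.

The compounds shown leave open whether an amine or a carboxylic acid at this same place would also stay within the scatter, or whether a group of that kind would finally separate itself from hydrogen, chloro and methoxy. They also leave open whether methoxy or chloro on another carbon of this ring would give the same flat picture, since all three compounds speak for one place only.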